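The source may hold more compounds than are shown below. What is called first, only, known or untested is meant among the compounds shown, and "the series" means these compounds.

Measured in a functional assay on SGC-7901 cells (Homo sapiens) for antiproliferative activity, read by MTT assay, with a stated time of 72 h; a lower number here means a stronger inhibitor, a higher number a weaker inhibitor:
- compound 1 `CCOC(=O)c1cc(-c2cc(OC)c(OC)c(OC)c2)c(-c2ccc(OC)cc2)s1`: 9760 nM
- compound 2 `COc1ccc(-c2sc(C(=O)O)cc2-c2cc(OC)c(OC)c(OC)c2)cc1`: 7800 nM
- compound 3 `COc1ccc(-c2sc(C(=O)O)cc2-c2cc(OC)c(OC)c(OC)c2)cc1[N+](=O)[O-]`: 23300 nM

Compound 2, at 7800 nM, cannot be separated from compound 1, since a 1.3-fold lower number from compound 1 to compound 2 (0.10 log units; within the scatter) lies within the scatter. Compound 3 sits clearly higher, with a 3.0-fold higher number from compound 2 to compound 3 (0.48 log units; beyond the scatter) beyond the scatter. The next compound, compound 4 `COc1cc(-c2cc(C(=O)O)sc2-c2ccc3ccccc3c2)cc(OC)c1OC`, carries naphthalen-2-yl in place of 4-methoxyphenyl on an aromatic carbon.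

The step at the carbonyl end, from compound 1 to compound 2, concerns a different part of the molecule and says little here. Only the modest rise from compound 2 to compound 3 touches the 4-methoxyphenyl group, and it adds nitro rather than replacing the group. Within the data shown here, no measured step exchanges that group outright, so the evidence is thin. On the strength of a 3.0-fold higher number from compound 2 to compound 3 (0.48 log units; beyond the scatter), a small step upward in this assay is expected, possibly none beyond the scatter. The expected change is a 1.3-fold higher number from compound 2 to compound 4 (0.11 log units; within the scatter). Compound 4 is estimated at 10000 nM, with an expected range of 3500 nM to 28000 nM.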

Compound 4, half-maximal inhibitory concentration: 380 nM
Compound 4: middle estimate off by 26-fold (1.42 log units), on the high side; measured number below the stated range.
By their numbers in this assay, from the lowest: compound 4; then compounds 2 and 1 (each within the scatter of the next); then compound 3.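

In this assay, the outright exchange of 4-methoxyphenyl for naphthalen-2-yl gives a 21-fold lower number from compound 2 to compound 4 (1.31 log units; beyond the scatter). Among these compounds, until now, the only change at this group was the addition of nitro, with a 3.0-fold higher number from compound 2 to compound 3 (0.48 log units; beyond the scatter), so the earlier compounds showed only a modest rise in the number. This position next to the ring sulfur can therefore move the number far more, and in the opposite direction, when the whole group is replaced; no measurement shown here accounts for that drop.

The single step changes several things at once, since the methoxy oxygen leaves and a second six-membered aromatic ring enters, and the compounds shown do not separate the two. A plain phenyl, a naphthalen-1-yl or a 4-ethoxyphenyl at this place would be needed to tell how much each part contributes.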